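This account rests on a few compounds, and the source may have more. Where it says the series, first, only, none or still open, it means among the compounds named here.

Working notes on the cytotoxicity series. Compound 1 `O=C1/C(=C/c2cccc(F)c2)CN(S(=O)(=O)c2ccc(O[N+](=O)[O-])cc2)C/C1=C\c1cccc(F)c1` gives 10700 nM in an ADME assay on L02 cells (Homo sapiens) for cytotoxicity, read by MTT assay, with a stated time of 24 h; a lower number here means a stronger inhibitor, a higher number a weaker inhibitor. Compound 2 `O=C1/C(=C/c2cccc(F)c2)CN(S(=O)(=O)c2ccc(C(F)(F)F)cc2)C/C1=C\c1cccc(F)c1` gives 18000 nM in this assay. The change from compound 1 to compound 2 is trifluoromethyl in place of nitrooxy on an aromatic carbon and it made a 1.7-fold higher number from compound 1 to compound 2 (0.23 log units; within the scatter). Compound 3 `O=C1/C(=C/c2ccc(F)cc2)CN(S(=O)(=O)c2ccc(O[N+](=O)[O-])cc2)C/C1=C\c1ccc(F)cc1` gives 16200 nM in this assay; its core differs from the core of compound 1, and the difference between the two cores is not broken down here. Compound 4 `O=C1/C(=C/c2ccc(F)cc2)CN(S(=O)(=O)c2ccc(C(F)(F)F)cc2)C/C1=C\c1ccc(F)cc1` carries the same change on the core of compound 3, namely (trifluoromethyl in place of nitrooxy on an aromatic carbon). A step of similar size is expected from compound 3 to compound 4, a 1.5-fold higher number from compound 3 to compound 4 (0.17 log units; within the scatter), because the same change gave a 1.7-fold higher number from compound 1 to compound 2 (0.23 log units; within the scatter). For compound 4 the expected value in this assay is 24000 nM, estimated to lie between 10000 nM and 55000 nM.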

Compound 4, half-maximal inhibitory concentration: 13500 nM
Estimate against measurement, compound 4: 1.8-fold (0.25 log units) above; the measured number falls inside the stated range.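

In this assay, among the compounds shown here, trifluoromethyl in place of nitrooxy gives a 1.2-fold lower number from compound 3 to compound 4 (0.08 log units; within the scatter), and the two steps for this replacement do not separate: the same change on two cores in this assay, a 1.7-fold higher number (0.23 log units; within the scatter) from compound 1 to compound 2 and a 1.2-fold lower number (0.08 log units; within the scatter) from compound 3 to compound 4, 2.0-fold (0.31 log units) apart, within the scatter of two such steps On these two cores, the replacement therefore gives no step that can be told from the scatter, and the two steps agree only in that sense. This does not give the replacement a direction, and two pairs in one assay do not show that the result would hold on any other core.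

Open, on these data alone, is whether an amine or a carboxylic acid in place of nitrooxy would give a step beyond the scatter on either core. Also open, as far as these compounds go, is whether the replacement reads the same on a core with methoxy in place of fluorine.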